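Cyclopropyl ketone in place of the aryl ketone

A few compounds are considered here, and "the series" means these few. Any claim that something is new, unique, unknown or untested is made for them only; others in the source may bear on it.

Values in a functional assay on HCT-116 cells (Homo sapiens) for inhibition, read by MTT assay, with a stated time of 48 h (on this read-out lower numbers stand for stronger inhibition and higher numbers for weaker inhibition), each one a limit and not a number:
- compound 1 `COc1ccc(-n2c(SCC(=O)C3CC3)nnc2-c2cc(OC)c(OC)c(OC)c2)cc1`: > 60000 nM
- compound 2 `CCSc1nnc(-c2cc(OC)c(OC)c(OC)c2)n1-c1ccc(N(C)C)cc1`: > 60000 nM
- compound 3 `COc1ccc(C(=O)CSc2nnc(-c3cc(OC)c(OC)c(OC)c3)n2-c2ccc(N(C)C)cc2)cc1O`: > 100000 nM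

Compound 3 gives only a limit, (the limit of > 100000 nM in this assay, at which 1 of the 3 values shown sits). Compound 4 `COc1cc(-c2nnc(SCC(=O)C3CC3)n2-c2ccc(N(C)C)cc2)cc(OC)c1OC` differs from compound 3 by cyclopropyl in place of 3-hydroxy-4-methoxyphenyl on a carbonyl carbon. For the measured compounds named here, the one measured step bearing on this change, a step that the two limits leave unreadable from compound 2 to compound 3, gives no size or direction. Cyclopropylcarbonyl also occurs in compound 1, which gives only the limit > 60000 nM. No step beyond the scatter is therefore expected in this assay, and the estimated step is an at least 1.6-fold lower number from compound 3 to compound 4 (0.22 log units; that floor lies within the scatter). For compound 4 the estimate is 60000 nM, with an expected range of 20000 nM to 150000 nM.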

Compound 4, half-maximal inhibitory concentration: > 60000 nM
Compound 4 ended at the assay's limit; the forecaster's own chance of this, stated with the estimate: 80%; the middle value lies on the limit itself.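

In this assay compound 4 gives > 60000 nM, a limit and not a number, and its steps from compound 1, compound 2 and compound 3 cannot be read. From the compounds shown here alone, whether any of these groups changes inhibition in this assay stays open.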